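Phenylsulfonyl in place of methoxy on the shared core

The source may hold more compounds than are shown below. What is called first, only, known or untested is meant among the compounds shown, and "the series" means these compounds.

Values in a functional assay on T98G cells (Homo sapiens) for inhibition, read by colorimetric assay and MTT assay, with a stated time of 72 h (a higher number here means a weaker inhibitor, a lower number a stronger inhibitor), for the measured compounds:
- compound 1 `C=CCCCCOc1ccccc1-c1cnc(OCCC=C)n1C` at 29000 nM
- compound 2 `C=CCCCCOc1ccccc1-c1cnc(OCCCC=C)n1C` at 3000 nM
- compound 3 `C=CCCCCOc1ccccc1-c1cnc(OC)n1C` at > 100000 nM (a limit, not a number)

Compound 3 gives only a limit in this assay at > 100000 nM on this scale. The change to compound 4 `C=CCCCCOc1ccccc1-c1cnc(S(=O)(=O)c2ccccc2)n1C` is phenylsulfonyl in place of methoxy on an aromatic carbon.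

The measured steps at this carbon all involve chains, not a sulfonyl group. They are an at least 3.4-fold higher number from compound 1 to compound 3 (0.53 log units; beyond the scatter) and an at least 33-fold higher number from compound 2 to compound 3 (1.52 log units; beyond the scatter) and both end at methoxy. Along the chains themselves there is a 9.7-fold lower number from compound 1 to compound 2 (0.99 log units; beyond the scatter) so the outcome depends strongly on the group. A modest step to a lower number is therefore expected, with wide uncertainty.

The estimate for compound 4 is 20000 nM (expected range 3000 nM to 100000 nM). The expected change is an at least 5.0-fold lower number from compound 3 to compound 4 (0.69 log units; beyond the scatter) and a second limit remains possible.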

Compound 4, half-maximal inhibitory concentration: 71000 nM
Compound 4: the middle estimate sits 3.6-fold (0.55 log units) below what was measured; measured number inside the range.
By their numbers in this assay, from the lowest: compound 2; then compound 1; then compound 4. At a limit, above all of these: compound 3.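

Phenylsulfonyl shows that a group other than a chain on this aromatic carbon can still give a number in this assay, but it does not match either chain, with a 2.4-fold higher number from compound 1 to compound 4 (0.39 log units; beyond the scatter) and a 24-fold higher number from compound 2 to compound 4 (1.37 log units; beyond the scatter). Against methoxy the step is an at least 1.4-fold lower number from compound 3 to compound 4 (0.14 log units; that floor lies within the scatter), so no gain over methoxy is established. Compound 3 is only a limit of the assay: the limit of > 100000 nM in this assay, at which 1 of the 4 values shown sits.

Still open, from the compounds shown here alone, is whether an amine or a carboxylic acid on this carbon would hold up as well as phenylsulfonyl. Also open, going by these compounds, is whether a chain longer than (pent-4-en-1-yl)oxy would lower the number further than compound 2 does.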